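Swapping the Aryl Group on the Shared Core

The source may report more compounds than this note shows. Statements on the series, on what has been measured and on what is new or still open speak of the compounds shown alone.

Compound 1 `COc1ccccc1Oc1c(N)nc(-c2ccc(C)cc2)nc1Cl` gives 17400 nM in a functional assay on B16 cells (Mus musculus) for cytotoxicity, read by CCK-8 assay, with a stated time of 24 h; a lower number here means a stronger inhibitor, a higher number a weaker inhibitor.
Compound 2 `COc1ccccc1Oc1c(N)nc(-c2cccc(Cl)c2)nc1Cl` gives 17900 nM in this assay.
Compound 3 `COc1ccccc1Oc1c(N)nc(-c2ccc(C)cc2)nc1OCCO` gives 8430 nM in this assay.

Compound 3 holds the lowest of the three numbers. It sits a 2.1-fold lower number from compound 1 to compound 3 (0.31 log units; beyond the scatter), and its gap to compound 2 is also beyond the scatter, so on these values compound 3 is the strongest inhibitor of the three. Compound 4 `COc1ccccc1Oc1c(N)nc(-c2cccc(I)c2)nc1OCCO` has not yet been measured. It differs from compound 3 in a single place: 3-iodophenyl in place of 4-methylphenyl on an aromatic carbon. Within the data shown here, the one measured step that bears on this change is the exchange of the same aromatic group in the other pair, a 1.0-fold higher number from compound 1 to compound 2 (0.01 log units; within the scatter), which left the number essentially where it was. The group entering here is 3-iodophenyl rather than 3-chlorophenyl, so that step is a guide and not a match, and nothing else among the three compounds speaks to the question. On that basis the expected step is a 1.1-fold lower number from compound 3 to compound 4 (0.02 log units; within the scatter), that is, no change beyond the scatter in either direction. Compound 4 is therefore estimated at 8000 nM, with a likely range from 3500 nM to 19000 nM.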

Compound 4, half-maximal inhibitory concentration: 20300 nM
Compound 4: middle estimate off by 2.5-fold (0.40 log units), on the low side, outside the stated range (above it).
By their numbers in this assay, from the lowest: compound 3; then compounds 1, 2 and 4 (each within the scatter of the next).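

In this assay, replacing 4-methylphenyl with 3-iodophenyl gives a 2.4-fold higher number from compound 3 to compound 4 (0.38 log units; beyond the scatter), a weakening beyond the scatter, so the aryl group at this position can matter. The earlier aryl swap did not show this: it gave a 1.0-fold higher number from compound 1 to compound 2 (0.01 log units; within the scatter), which is within the scatter. The two swaps differ in the entering group, 3-iodophenyl against 3-chlorophenyl, and in the group on the shared core, 2-hydroxyethoxy against chloro, and no measurement here explains the weakening.

The compounds shown leave open whether the larger step comes from the iodine itself or from pairing the aryl swap with 2-hydroxyethoxy, a question that 3-chlorophenyl alongside 2-hydroxyethoxy, or 3-iodophenyl alongside chloro, could help to settle. They also leave open how this position responds to aryl groups carrying an amine or a carboxylic acid, and whether moving iodine to the 4-position of the phenyl ring changes the number.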